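Anilide Swap on a Core Inert to Colon Cells

This account rests on a few compounds, and the source may have more. Where it says the series, first, only, none or still open, it means among the compounds named here.

Compound 1 `COc1ccc(OC)c(NC(=O)c2cccc(/C=C3\CC(=O)N(c4ccccc4)C3=O)c2)c1` was tested in an ADME assay on NCM460 cells (Homo sapiens) for cytotoxicity, read by MTT assay, with a stated time of 72 h; a lower number here means a stronger inhibitor, a higher number a weaker inhibitor. In this assay compound 1 gives only a limit, > 100000 nM. Compound 2 `CCCCCN1C(=O)C/C(=C\c2cccc(C(=O)Nc3ccc(OC)cc3)c2)C1=O` also gives only a limit in this assay, > 100000 nM. Compound 1 thus stands at the limit of > 100000 nM in this assay, at which 2 of the 2 values shown sit, with no numbered value anywhere in the series. Compound 3 `CCc1ccc(NC(=O)c2cccc(/C=C3\CC(=O)N(c4ccccc4)C3=O)c2)cc1` carries 4-ethylphenyl in place of 2,5-dimethoxyphenyl on an amide-type nitrogen. Among the measured compounds shown here, no measured step connects any two compounds here, so the change is expected to shift this assay by nothing beyond the scatter, in no particular direction. The expected step of a number no higher from compound 1 to compound 3 (the limit leaves the size open) is accordingly flat. Compound 3 is expected to give 100000 nM, between 30000 nM and 300000 nM, most probably reported again as a limit.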

Compound 3, half-maximal inhibitory concentration: > 100000 nM
Compound 3: a limit, no number; the forecaster's own chance of this, stated with the estimate: 80%; the middle value sits exactly at the limit.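

Among the compounds shown here, compound 1 and compound 3 both give only a limit in this assay, so no step between them can be read. The compounds shown leave open what numbered value, if any, this series could reach in this assay.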